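Chain length at the propargylic carbon: butyl to methyl

The compounds below may be only part of what the source reports. "The series", "measured", "known", "first", "only" and "open" are said of these compounds alone.

Measured so far:
- compound 1, `COC(=O)C#CC(O/C=C/C(=O)OC)C(C)C`: 750 nM
- compound 2, `COC(=O)C#CC(O/C=C/C(=O)OC)C1CCCCC1`: 2100 nM
- compound 3, `CCCCC(C#CC(=O)OC)O/C=C/C(=O)OC`: 240 nM

In a functional assay on SW1573 cells (Homo sapiens) for antiproliferative activity, read by sulforhodamine B assay, with a stated time of 48 h (a lower number here means a stronger inhibitor of growth, a higher number a weaker inhibitor of growth), compound 3 gives the lowest number of the three. Against compound 1 the change is a 3.1-fold lower number from compound 1 to compound 3 (0.49 log units; beyond the scatter), and against compound 2 it is an 8.8-fold lower number from compound 2 to compound 3 (0.94 log units; beyond the scatter); the step of a 2.8-fold higher number from compound 1 to compound 2 (0.45 log units; beyond the scatter) shows the larger saturated ring giving the higher number.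

Compound 4, `COC(=O)C#CC(C)O/C=C/C(=O)OC`, is not yet measured. It differs from compound 3 by hydrogen in place of propyl on a saturated chain carbon, two bonds along the chain from an oxygen on an unsaturated carbon and a triple-bonded carbon. For the measured compounds named here, no measured step removes carbons from a chain at this place; the two steps toward compound 3 only show the butyl chain giving the lower number. The step of a 3.8-fold higher number from compound 3 to compound 4 (0.57 log units; beyond the scatter) is therefore expected to be a modest higher number. Compound 4 is estimated at 900 nM, within 300 nM to 2700 nM.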

Compound 4, concentration for 50% growth inhibition: 1700 nM
The estimate for compound 4 lay 1.9-fold (0.28 log units) below the measured number; the range from low to high includes it.
By their numbers in this assay, from the lowest: compound 3; then compound 1; then compounds 4 and 2 (each within the scatter of the next).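

In this assay, the straight chain at this carbon now has two lengths, and butyl gives way to methyl with a clear loss (a 7.1-fold higher number from compound 3 to compound 4 (0.85 log units; beyond the scatter)). The low number of compound 3 therefore belongs to the butyl chain, while methyl does not improve on isopropyl (a 2.3-fold higher number from compound 1 to compound 4 (0.36 log units; beyond the scatter)). Methyl and cyclohexyl are not separated (a 1.2-fold lower number from compound 2 to compound 4 (0.09 log units; within the scatter)), so the number does not follow carbon count across the series, with compound 2 going against any such trend. Going by these compounds, whether a longer chain such as hexyl lowers the number further, or a chain ending in an amine keeps it, stays open. Nothing on hand explains these steps.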